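Methyl for Methoxy: A Small Swap on Compound 1

A few compounds are considered here, and "the series" means these few. Any claim that something is new, unique, unknown or untested is made for them only; others in the source may bear on it.

In a functional assay on MDA-MB-231 cells (Homo sapiens) for cytotoxicity, read by MTT assay, with a stated time of 48 h (a higher number here means a weaker inhibitor, a lower number a stronger inhibitor), compound 1 `COc1ccc(-n2cc(CCCOS(=O)(=O)c3ccc(C)cc3)nn2)cc1` gives 72800 nM. Among the measured compounds shown here, this is the only number available, so compound 1 cannot yet be ranked against anything. A second compound, compound 2 `COC(=O)c1ccc(-n2cc(CCCOS(=O)(=O)c3ccc(-c4ccccc4)cc3)nn2)cc1`, carries the entry "not determined" (no result reported) and so offers no comparison.

Still unmeasured is compound 3 `Cc1ccc(-n2cc(CCCOS(=O)(=O)c3ccc(C)cc3)nn2)cc1`, which keeps the rest of compound 1 and differs at one place: methyl in place of methoxy on an aromatic carbon. In words, it has methyl in place of methoxy on an aromatic carbon, the change from 4-methoxyphenyl to 4-methylphenyl. For the measured compounds named here, no measured pair shows what this swap does, so there is no direct precedent to draw on. The expectation rests on compound 1 at 72800 nM and on the modest size of the edit. The estimated step of a 1.1-fold lower number from compound 1 to compound 3 (0.03 log units; within the scatter) is expected to have no clear direction and to stay within the usual scatter of repeated measurements. In this assay, the estimate for compound 3 is 68000 nM, with an expected range from 32000 nM to 130000 nM.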

Compound 3, half-maximal inhibitory concentration: 36600 nM
The estimate for compound 3 lay 1.9-fold (0.27 log units) above the measured number; the range from low to high includes it.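

Among the compounds shown here, this is the only measured pair at this position, an aromatic carbon para to a large group, and methyl in place of methoxy there gives a 2.0-fold lower number from compound 1 to compound 3 (0.30 log units; within the scatter) in this assay. Removing the methoxy group, with its one hydrogen-bond acceptor, and adding a methyl group with none therefore leaves a difference that repeated measurements of the same compound could also show, so this pair cannot separate 4-methoxyphenyl from 4-methylphenyl. Nothing available explains the result or bears on how either group acts in these cells.

As far as these compounds go, one small swap tests only a narrow part of what this position might tolerate, so it remains open whether a larger or differently built group, such as an amine, a carboxylic acid or a longer alkyl chain, would shift the number beyond the scatter. From the compounds shown here alone, it also remains open whether methyl and methoxy would stay this close if another part of the core of compound 1 were changed, and compound 2 cannot help because it has no reported result.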